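The source may report more compounds than this note shows. Statements on the series, on what has been measured and on what is new or still open speak of the compounds shown alone.

Compound 1 `CCNC1=NS(=O)(=O)c2cc(F)ccc2N1` carries an ethylamino group on the shared core. In a functional assay (aorta) with Rattus norvegicus as the target (a higher number here means that more compound is needed for the effect, a lower number that less compound is needed), compound 1 gives only a limit, > 300 uM (the limit of > 300 uM in this assay, at which 1 of the 3 values shown sits). Compound 2 `CC(C)NC1=NS(=O)(=O)c2cc(F)ccc2N1` differs by methyl in place of hydrogen on a saturated chain carbon bound to an amine nitrogen and a saturated chain carbon and in this assay gives 43.1 uM, a step of an at least 6.9-fold lower number from compound 1 to compound 2 (0.84 log units; beyond the scatter). Compound 3 `CCC(C)NC1=NS(=O)(=O)c2cc(Br)ccc2N1` has a core whose difference from that of compound 1 is not broken down here; in this assay compound 3 gives 5.6 uM, the lowest of the two numbers.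

Compound 4 `CC(C)C(C)NC1=NS(=O)(=O)c2cc(Br)ccc2N1` is not yet measured and differs from compound 3 by methyl in place of hydrogen on a saturated chain carbon bound to two saturated chain carbons. This is the same kind of change as from compound 1 to compound 2, but not the same: there the place is on a saturated chain carbon bound to an amine nitrogen and a saturated chain carbon, here on a saturated chain carbon bound to two saturated chain carbons. A smaller step than the earlier one is expected, a 1.8-fold lower number from compound 3 to compound 4 (0.24 log units; within the scatter). Among the compounds with values here, the single measured instance sits at a different place and starts from a limit, so its size carries little weight. In this assay compound 4 is estimated at 3.2 uM, between 1 uM and 10 uM.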

Compound 4, concentration for half-maximal effect: 2.6 uM
The estimate for compound 4 lay 1.2-fold (0.09 log units) above the measured number, within the range that was stated.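

In this assay, methyl in place of hydrogen again gives a lower number, a 2.2-fold lower number from compound 3 to compound 4 (0.33 log units; beyond the scatter), so the direction holds on the core of compound 3, but the change sits at a different place in the chain, and the effects of core and place cannot be separated. The size of the step does not carry over: the same change on two cores in this assay, an at least 6.9-fold lower number (0.84 log units; beyond the scatter) from compound 1 to compound 2 and a 2.2-fold lower number (0.33 log units; beyond the scatter) from compound 3 to compound 4, at least 3.2-fold (0.50 log units) apart, beyond the scatter of two such steps

Compound 1 gives only a limit, > 300 uM.

On these data alone, it remains open whether a longer chain or a cyclopentyl group in place of the 1,2-dimethylpropyl group would lower the number further. As far as these compounds go, the effect of an amine or a carboxylic acid on that chain also remains open.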